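Adding a Fluoro Group to a Chloro-Bearing Core

This account rests on a few compounds, and the source may have more. Where it says the series, first, only, none or still open, it means among the compounds named here.

Compound 3 `O=c1c(C2N=C(c3ccccc3)SS2)coc2cc(Cl)ccc12` belongs to a small set of close relatives. Within the data shown here, in a functional assay on IMR-32 cells (Homo sapiens) for inhibition, read by sulforhodamine B assay, with a stated time of 48 h (on this read-out higher numbers stand for weaker inhibition and lower numbers for stronger inhibition), compound 3 gives 95100 nM, the highest of the three numbers measured so far. Among the measured compounds shown here, its nearest neighbour is compound 1 `O=c1c(C2N=C(c3ccccc3)SS2)coc2cc(Cl)c(Cl)cc12`, which gives 58000 nM; the single measured step, a 1.6-fold higher number from compound 1 to compound 3 (0.21 log units; within the scatter), lies within the scatter. For the measured compounds named here, compound 2 `O=c1c(C2N=C(c3ccccc3)SS2)coc2ccc(F)cc12`, which carries a fluoro group instead of a chloro group, gives 14600 nM, a number well below that of compound 3; no single-change step connects these two, so only their two values can be compared.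

Compound 4 `O=c1c(C2N=C(c3ccccc3)SS2)coc2cc(Cl)c(F)cc12` is the next step: fluoro in place of hydrogen on an aromatic carbon. Going by the values given here, the only measured step that bears on this change is the one from compound 1 to compound 3, which removed a chloro group from the very carbon that now receives a fluoro group; its size was within the scatter. Since a halogen at this place made little difference there, the expected step of a 1.6-fold lower number from compound 3 to compound 4 (0.20 log units; within the scatter) is small, with no clear direction beyond the scatter. Compound 4 is therefore estimated to give 60000 nM in this assay, with a range from 20000 nM to 180000 nM.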

Compound 4, half-maximal inhibitory concentration: 56800 nM
Beside the measured number, compound 4's estimate is 1.1-fold (0.02 log units) above it; measured number inside the range.
By their numbers in this assay, from the lowest: compound 2; then compounds 4, 1 and 3 (each within the scatter of the next).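

On the core that keeps its chloro group, fluoro on this aromatic carbon gives a step that stays within the scatter in this assay, a 1.7-fold lower number from compound 3 to compound 4 (0.22 log units; within the scatter), and putting fluoro in place of chloro there does the same, a 1.0-fold lower number from compound 1 to compound 4 (0.01 log units; within the scatter), so hydrogen, fluoro and chloro at this carbon cannot be told apart on that core. Among these compounds, compound 4 also opens a new comparison with compound 2: adding a chloro group to that fluoro-bearing compound gives a 3.9-fold higher number from compound 2 to compound 4 (0.59 log units; beyond the scatter), the only step in this part of the series that lies beyond the scatter. The size of a swap between chloro and hydrogen therefore depends on the compound that carries it, although the two steps do not involve the same carbon: the same change on two cores in this assay, a 1.6-fold higher number (0.21 log units; within the scatter) from compound 1 to compound 3 and a 3.9-fold lower number (0.59 log units; beyond the scatter) from compound 4 to compound 2, 6.4-fold (0.80 log units) apart, beyond the scatter of two such steps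

The compounds shown leave open whether a group other than a halogen on this carbon, such as a methoxy group or an amine, would also stay within the scatter. They also leave open how the core would read with hydrogen on both of these carbons, which would show what each halogen does on its own.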